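From thiophen-3-yl to 2-hydroxyphenyl on a shared core

The source may hold more compounds than are shown below. What is called first, only, known or untested is meant among the compounds shown, and "the series" means these compounds.

In a functional assay on HOS cells (Homo sapiens) for inhibition, with a stated time of 72 h (a higher number here means a weaker inhibitor, a lower number a stronger inhibitor), compound 1 `NC1CCC(Nc2nc(NCc3ccc(-c4ccccc4)nc3)c3ncn(C4CCCC4)c3n2)CC1` gives 206 nM, compound 2 `NC1CCC(Nc2nc(NCc3ccc(-c4cccc(F)c4)nc3)c3ncn(C4CCCC4)c3n2)CC1` gives 44 nM and compound 3 `NC1CCC(Nc2nc(NCc3ccc(-c4ccsc4)nc3)c3ncn(C4CCCC4)c3n2)CC1` gives 89 nM. Compound 3 therefore holds the middle of the three numbers, with compound 2 lower and compound 1 higher. Compound 4 `NC1CCC(Nc2nc(NCc3ccc(-c4ccccc4O)nc3)c3ncn(C4CCCC4)c3n2)CC1` has not yet been measured. It differs from compound 3 as follows: 2-hydroxyphenyl in place of thiophen-3-yl on an aromatic carbon. In short, 2-hydroxyphenyl stands in place of thiophen-3-yl on an aromatic carbon.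

All three measured steps concern this same group. The data show a 4.7-fold lower number from compound 1 to compound 2 (0.67 log units; beyond the scatter) and a 2.3-fold lower number from compound 1 to compound 3 (0.36 log units; beyond the scatter), followed by a 2.0-fold higher number from compound 2 to compound 3 (0.31 log units; beyond the scatter). Each is beyond the scatter but modest, so changes here have so far moved this assay only moderately. Within the data shown here, no measured compound carries a hydroxyl group, so the data do not show what this substituent does. The nearest comparison is compound 1 at 206 nM, which shares the six-membered carbon ring, while compound 2 at 44 nM shows that a substituted phenyl can reach a lower number. A small move towards a higher number is therefore expected, at most modest in size. The estimated step is a 1.3-fold higher number from compound 3 to compound 4 (0.13 log units; within the scatter). For compound 4 the expected value is 120 nM, with an estimated range from 40 nM to 350 nM.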

Compound 4, half-maximal inhibitory concentration: 14 nM
For compound 4 the middle estimate is 8.6-fold (0.93 log units) above the measured one; measured number outside the range, below it.
By their numbers in this assay, from the lowest: compound 4; then compound 2; then compound 3; then compound 1.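

In this assay the 2-hydroxyphenyl group gives the lowest number of the four compounds, with a 6.4-fold lower number from compound 3 to compound 4 (0.80 log units; beyond the scatter) and a 3.1-fold lower number from compound 2 to compound 4 (0.50 log units; beyond the scatter) both beyond the scatter. Among these compounds, the clearest reading comes from the comparison with the unsubstituted phenyl, where hydroxy replaces a single hydrogen on an aromatic carbon, giving a 15-fold lower number from compound 1 to compound 4 (1.17 log units; beyond the scatter) and the only step printed as large. Among the compounds shown here, this shows that the aryl group on the pyridine-type ring, which had so far moved the number only modestly, can move it much further, and that a single added hydroxyl is enough to do so, though no evidence on the reason for this is at hand.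

The compounds shown leave open whether the hydrogen-bond donor counted for the hydroxyl matters at all, since a methoxy group or an amine in the same place would be needed to separate the hydroxyl from any other substituent. They also leave open whether the hydroxyl would lower the number on other rings, such as the thiophen-3-yl of compound 3, or together with the fluoro of compound 2.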